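The compounds below may be only part of what the source reports. "The series", "measured", "known", "first", "only" and "open" are said of these compounds alone.

- Compound 1 `Cc1ccc(-c2nc3ccccn3c2Sc2ccccc2)cc1`: 86700 nM
- Compound 2 `N#Cc1ccc(-c2nc3ccccn3c2Sc2ccccc2)cc1`: 64200 nM

In a functional assay on HeLa cells (Homo sapiens) for inhibition, read by MTT assay, with a stated time of 48 h (a higher number here means a weaker inhibitor, a lower number a stronger inhibitor), compound 2 gives 64200 nM, which cannot be told apart from the value of compound 1. Compound 3 `c1ccc(Sc2c(-c3ccsc3)nc3ccccn23)cc1` has thiophen-3-yl in place of 4-cyanophenyl on an aromatic carbon. Among the measured compounds shown here, the only measured step, a 1.4-fold lower number from compound 1 to compound 2 (0.13 log units; within the scatter), changed a group on the aromatic ring but kept the ring itself, so it bears only loosely on this swap. For the measured compounds named here, no measured step replaces that ring. With so little evidence, no shift beyond the scatter is expected, and the expected change is a 1.1-fold higher number from compound 2 to compound 3 (0.04 log units; within the scatter). For compound 3 the estimated value is 70000 nM, with an expected range of 30000 nM to 150000 nM.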

Compound 3, half-maximal inhibitory concentration: 76000 nM
Beside the measured number, compound 3's estimate is 1.1-fold (0.04 log units) below it, and the stated range covers the measured number.
By their numbers in this assay, from the lowest: compounds 2, 3 and 1 (each within the scatter of the next).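

Replacing the ring itself at this position gives a 1.2-fold higher number from compound 2 to compound 3 (0.07 log units; within the scatter) in this assay and, with 4-methylphenyl as the group replaced, a 1.1-fold lower number from compound 1 to compound 3 (0.06 log units; within the scatter) as well. A five-membered aromatic ring with one sulfur can therefore stand in for either six-membered carbon ring here without a change that can be told from the scatter. No measurement available gives a reason for this. Still open, from the compounds shown here alone, is whether a phenyl ring bearing an amine or a carboxylic acid, or a plain alkyl chain with no ring at all, would shift the number beyond the scatter at this position.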